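A few compounds are considered here, and "the series" means these few. Any claim that something is new, unique, unknown or untested is made for them only; others in the source may bear on it.

Compound 1 `CCCCOC(=O)NS(=O)(=O)c1sc(CC(C)C)cc1-c1ccc(Cc2nccs2)cc1` and compound 2 `CCCCOC(=O)NS(=O)(=O)c1sc(CC(C)C)cc1-c1ccc(Cn2cnc(C(F)(F)F)c2)cc1` share one core and differ at a single place. Within the data shown here, in an assay on membranes from uterus for displacement of a labelled ligand from Angiotensin type II receptor (Sus scrofa), with a stated time of 1.5 h (a higher number here means a weaker inhibitor, a lower number a stronger inhibitor), compound 1 gives 3.2 nM, and compound 2 gives 7.3 nM, the higher of the two numbers so far. Among the measured compounds shown here, the only measured step is a 2.3-fold higher number from compound 1 to compound 2 (0.36 log units; beyond the scatter). Compound 3 `CCCCOC(=O)NS(=O)(=O)c1sc(CC(C)C)cc1-c1ccc(C(=O)c2cccs2)cc1` has not yet been measured. It differs from compound 2 in that (a group of 7 heavy atoms (5 carbon, 1 oxygen, 1 sulfur; one five-membered aromatic ring with 1 hetero atom) in place of a group of 10 heavy atoms (5 carbon, 2 nitrogen, 3 fluorine; one five-membered aromatic ring with 2 hetero atoms), on an aromatic carbon). For the measured compounds named here, no measured step exchanges a whole ring for a carbonyl-linked ring, so the one measured step sets only the scale of change seen so far, and the step of a 1.2-fold lower number from compound 2 to compound 3 (0.09 log units; within the scatter) is expected to be small, in no clear direction. Compound 3 is therefore estimated at 6 nM, within 2 nM to 25 nM.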

Compound 3, inhibition constant: 18.8 nM
Compound 3: the middle estimate sits 3.1-fold (0.50 log units) below what was measured; the range from low to high includes it.
By their numbers in this assay, from the lowest: compound 1; then compound 2; then compound 3.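

The carbonyl-linked thiophene gives the highest number of the three in this assay (a 2.6-fold higher number from compound 2 to compound 3 (0.41 log units; beyond the scatter)), and the gap is wider against the methylene-linked thiazole (a 5.9-fold higher number from compound 1 to compound 3 (0.77 log units; beyond the scatter)). So the group on this aromatic carbon can move the number beyond the scatter, even though all three groups end in a five-membered aromatic ring. Nothing available explains this difference.

Between compound 1 and compound 3, the ring and its link change together, so their separate shares remain open. A (thiophen-2-yl)methyl group at this place would separate them.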